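The source may report more compounds than this note shows. Statements on the series, on what has been measured and on what is new or still open speak of the compounds shown alone.

Measured so far:
- Compound 1, `O=C([C@@H]1CCCN(S(=O)(=O)c2ccc(S(=O)(=O)C3CCC3)cc2)C1)N1CCC(F)(F)CC1`: 9 nM
- Compound 2, `O=C([C@@H]1CCCN(S(=O)(=O)c2ccc(S(=O)(=O)N3CC[C@H](O)C3)cc2)C1)N1CCC(F)(F)CC1`: 590 nM

Both compounds were tested in a functional assay on MIA PaCa-2 cells (Homo sapiens) for inhibition, read by MTT assay, with a stated time of 7 days; a higher number here means a weaker inhibitor, a lower number a stronger inhibitor. Among the compounds with values here, compound 2 gives the higher of the two numbers, and the only step that leads to it is a 66-fold higher number from compound 1 to compound 2 (1.82 log units; beyond the scatter), so compound 2 is the weaker inhibitor of the two by a margin well beyond the scatter.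

Compound 3, `CC(C)NS(=O)(=O)c1ccc(S(=O)(=O)N2CCC[C@@H](C(=O)N3CCC(F)(F)CC3)C2)cc1`, has not yet been measured. It differs from compound 2 by isopropylamino in place of 3-hydroxypyrrolidin-1-yl on a sulfonyl sulfur. Within the data shown here, the only measured step at this sulfonyl sulfur is the one from cyclobutyl to 3-hydroxypyrrolidin-1-yl, which is large, and it shows that this position is sensitive to what sits on it. Among the measured compounds shown here, no measured step replaces the 3-hydroxypyrrolidin-1-yl group with isopropylamino, so the direction of the new step can only be estimated. Since the group that enters is a short acyclic amine without the hydroxyl, a move back toward the number of compound 1 seems more likely than a move further away, but the size is uncertain. The expected step is a 4.9-fold lower number from compound 2 to compound 3 (0.69 log units; beyond the scatter). Compound 3 is therefore estimated at 120 nM, with a likely range from 25 nM to 600 nM.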

Compound 3, half-maximal inhibitory concentration: 350 nM
Estimate against measurement, compound 3: 2.9-fold (0.46 log units) below; low and high end bracket the measured number.
By their numbers in this assay, from the lowest: compound 1; then compounds 3 and 2 (each within the scatter of the next).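

In this assay, isopropylamino in place of 3-hydroxypyrrolidin-1-yl on the sulfonyl sulfur gives a 1.7-fold lower number from compound 2 to compound 3 (0.23 log units; within the scatter), so removing the ring and the hydroxyl together leaves compound 3 and compound 2 indistinguishable here. Isopropylamino in place of cyclobutyl gives a 39-fold higher number from compound 1 to compound 3 (1.59 log units; beyond the scatter), so a second group attached to the sulfur through nitrogen also stands far from cyclobutyl, which is attached through carbon, and among these three compounds none goes against that split. No measurement shown here explains the split.

The change from cyclobutyl to either nitrogen-linked group alters more than one feature, so the attaching atom cannot yet be separated from the shape of the group. An isopropyl group on the same sulfur would test an open chain attached through carbon, while cyclobutylamino would test the cyclobutyl ring attached through nitrogen, and together they would show whether the attaching atom or the ring carries the large difference.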